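A few compounds are considered here, and "the series" means these few. Any claim that something is new, unique, unknown or untested is made for them only; others in the source may bear on it.

Compound 1, `CCN(C)C(=O)N1CCN(C(=S)SCc2cn(Cc3ccccc3F)nn2)CC1`, in a functional assay on MGC-803 cells (Homo sapiens) for cytotoxicity, read by MTT assay, with a stated time of 72 h (a higher number here means a weaker inhibitor, a lower number a stronger inhibitor), gives 5860 nM.
Compound 2, `COc1cc(Cn2cc(CSC(=S)N3CCN(C(N)=O)CC3)nn2)cc(OC)c1OC`, in this assay gives only a limit of the assay, > 128000 nM.
Compound 3, `CCNC(=O)N1CCN(C(=S)SCc2cn(Cc3cc(OC)c(OC)c(OC)c3)nn2)CC1`, in this assay gives 101000 nM.

Among the two numbers shown, compound 3 stands highest; the nearest, compound 1, sits well below it, a gap beyond the usual scatter. Compound 4, `COc1cc(Cn2cc(CSC(=S)N3CCN(C(=O)NC(C)C)CC3)nn2)cc(OC)c1OC`, has not yet been measured in this assay. It differs from compound 3 by methyl in place of hydrogen on a saturated chain carbon bound to an amide-type nitrogen and a saturated chain carbon, so that the ethyl becomes an isopropyl on the ethylcarbamoyl group. Among the measured compounds shown here, the one measured step that bears on this is the growth of the same group from hydrogen to ethyl, an at least 1.2-fold lower number from compound 2 to compound 3 (0.10 log units; that floor lies within the scatter), a change that stays within the scatter; its size is only a floor, because the limit of > 128000 nM in this assay, at which 1 of the 3 values shown sits, applies to compound 2. On that basis the further methyl is expected to leave the number essentially where it is, and the step of a 1.1-fold lower number from compound 3 to compound 4 (0.05 log units; within the scatter) is estimated to lie within the scatter. Compound 4 is therefore expected to give about 90000 nM in this assay, with a range from 35000 nM to 200000 nM.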

Compound 4, half-maximal inhibitory concentration: > 128000 nM
Compound 4 was reported as a limit (the forecaster's own chance of this, stated with the estimate: 30%); middle value at least 1.4-fold (0.15 log units) from the limit.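

In this assay, replacing ethyl with isopropyl gives an at least 1.2-fold higher number from compound 3 to compound 4 (0.10 log units; that floor lies within the scatter); this is only a floor, so the change is not shown to exceed the scatter, yet a larger rise is not ruled out. Among the compounds sharing the core of compound 3, hydrogen and isopropyl on the carbamoyl group both end at a limit of the assay, leaving ethyl in compound 3 as the only one with a readable number. The step between compound 2 and compound 4 cannot be read, because the two compounds sit at the same limit: the limit of > 128000 nM in this assay, at which 2 of the 4 values shown sit.

The compounds shown leave open how a longer chain such as n-butyl, or a phenyl ring, would read at this place. They also leave open whether the ethyl to isopropyl change has any measurable size on this core.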